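Extending the acyl group on a shared core

The compounds below may be only part of what the source reports. "The series", "measured", "known", "first", "only" and "open" are said of these compounds alone.

The three measured compounds share one core, carrying a butylamino group and an amino group, and differ only in the substituent on the ring nitrogen. Compound 1 `CCCCNc1nc(N)nc2c1CN(C(C)=O)CC2` bears an acetyl group there; in an assay on HEK293 cells for agonist activity at Toll-like receptor 8 (Homo sapiens), read by a luciferase reporter, with a stated time of 6 h (a lower number here means that less compound is needed, a higher number that more compound is needed for the effect), compound 1 gives 0.5 uM. Compound 2 `CCCCNc1nc(N)nc2c1CN(Cc1cccc(Cl)c1Cl)CC2` carries a 2,3-dichlorophenyl on a saturated chain carbon bound to that ring nitrogen and gives 0.18 uM, while compound 3 `CCCCNc1nc(N)nc2c1CN(Cc1ccc(OC)cc1)CC2` carries a 4-methoxyphenyl at the same place and gives 0.08 uM. Among these three numbers compound 1 stands highest; the values of compound 2 and compound 3 both lie beyond the scatter below it. Among the measured compounds shown here, the one step that joins two measured compounds, a 2.3-fold lower number from compound 2 to compound 3 (0.35 log units; beyond the scatter), concerns the exchange of one aryl group for another and says nothing about a change within an acyl group.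

Compound 4 `CCCCNc1nc(N)nc2c1CN(C(=O)CC)CC2` differs from compound 1 by methyl in place of hydrogen on a saturated chain carbon bound to a carbonyl carbon, so that the acetyl becomes a propanoyl. For the measured compounds named here, no measured step tests this kind of change, and the acyl compound is the weakest of the set as it stands. Compound 4 is therefore expected to remain close to compound 1, with an estimated step of a 1.3-fold lower number from compound 1 to compound 4 (0.10 log units; within the scatter) that need not exceed the scatter. Compound 4 is estimated at 0.4 uM, within a range from 0.15 uM to 1.2 uM.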

Compound 4, minimum effective concentration: 0.4 uM
Beside the measured number, compound 4's estimate shows no gap at the digits printed; the measured number falls inside the stated range.
By their numbers in this assay, from the lowest: compound 3; then compound 2; then compounds 4 and 1 (each within the scatter of the next).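

Among the compounds shown here, the step in this assay of a 1.3-fold lower number from compound 1 to compound 4 (0.10 log units; within the scatter) is the first measured change within the acyl group on the ring nitrogen, and it lies within the scatter, so acetyl and propanoyl cannot be told apart at this position. The earlier compounds shown here showed only an exchange of one aryl group for another, whereas this step shows that methyl in place of hydrogen on a saturated chain carbon bound to a carbonyl carbon has no effect that can be read here, and compound 4 at 0.4 uM keeps a higher number than compound 2 at 0.18 uM and compound 3 at 0.08 uM in this series. No supporting data are available to explain why this change leaves the number within the scatter.

As far as these compounds go, a single added methyl is a small probe, so it remains open whether a longer chain such as butanoyl, or a benzoyl group, would move the number beyond the scatter. From the compounds shown here alone, it also remains open whether an amine or a carboxylic acid on a saturated chain carbon bound to a carbonyl carbon would be tolerated in the same way.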